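The source may hold more compounds than are shown below. What is called first, only, known or untested is meant among the compounds shown, and "the series" means these compounds.

Measured so far in an ADME assay on microsomes from liver (Rattus norvegicus, strain Sprague-Dawley) for metabolic stability, read by HPLC, using NADPH, with stated times of 5 min and 60 min, tested at 10 uM; a higher number here means that the compound lasts longer, a lower number that the compound disappears faster:
compound 1 `CC(C)(C)c1ccc(C(=O)NCc2ccc(NS(=O)(=O)C3CC3)cc2Cl)cc1` gives 0.55 h
compound 2 `CS(=O)(=O)Nc1ccc(CNC(=O)c2ccc(N3CCCC3)cc2)c(Cl)c1` gives 1.28 h
compound 3 `CC(F)(F)c1ccc(C(=O)NCc2ccc(NS(C)(=O)=O)cc2Cl)cc1` gives 2.35 h

Compound 2 stands second highest of the three numbers in this assay. Its nearest neighbour is compound 3, and the step of a 1.8-fold higher number from compound 2 to compound 3 (0.26 log units; within the scatter) lies within the scatter, so these two values are not separated. For the measured compounds named here, compound 1 is furthest away; its value in this assay sits beyond the scatter from that of compound 2, but no single-site step connects the two, so only the two values themselves speak here.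

The unmeasured compound is compound 4 `CS(=O)(=O)Nc1ccc(CNC(=O)c2ccc(S(F)(F)(F)(F)F)cc2)c(Cl)c1`. Relative to compound 2 the change is a group of 6 heavy atoms (5 fluorine, 1 sulfur; no ring) in place of a group of 5 heavy atoms (4 carbon, 1 nitrogen; one five-membered non-aromatic ring with 1 hetero atom), on an aromatic carbon. Going by the values given here, the only measured step that bears on this is a 1.8-fold higher number from compound 2 to compound 3 (0.26 log units; within the scatter), where the pyrrolidin-1-yl on the same aromatic carbon was likewise exchanged for a substituent without a ring, and that step stayed within the scatter. On that single precedent, the step expected in this assay is a 1.6-fold higher number from compound 2 to compound 4 (0.19 log units; within the scatter), within the scatter and leaning, if anywhere, upward. Compound 4 is accordingly estimated at 2 h, with a range from 0.9 h to 4.5 h.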

Compound 4, half-life: 2.3 h
Compound 4: middle estimate off by 1.2-fold (0.06 log units), on the low side; measured number inside the range.
By their numbers in this assay, from the lowest: compound 1; then compounds 2, 4 and 3 (each within the scatter of the next).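

At the aromatic carbon para to a large group, a third substituent now stands on the shared core in this assay, and the new steps are a 1.8-fold higher number from compound 2 to compound 4 (0.25 log units; within the scatter) and a 1.0-fold lower number from compound 3 to compound 4 (0.01 log units; within the scatter) with neither leaving the scatter. For the compounds shown here, the group of 5 fluorine and 1 sulfur atoms in compound 4 therefore cannot be told apart from the 1,1-difluoroethyl in compound 3 or the pyrrolidin-1-yl in compound 2, and a second ring-free exchange at this place now stands beside the single earlier precedent, again without a step beyond the scatter. Nothing available here explains the half-lives of these compounds.

On these data alone, whether any group at this place can produce a step beyond the scatter stays open, for instance a carboxylic acid, a primary amine or a longer alkyl chain on the same aromatic carbon. Compound 1 remains joined to the other compounds by no single-site step, so the place in its structure that accounts for its separation from compound 2 also stays unresolved.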